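This account rests on a few compounds, and the source may have more. Where it says the series, first, only, none or still open, it means among the compounds named here.

Three compounds built on a shared core were tested in an assay for inhibition of Amine oxidase [flavin-containing] A (Homo sapiens), read by fluorescence and spectrophotometry, using microsomes, with stated times of 30 min and 20 min; a higher number here means a weaker inhibitor, a lower number a stronger inhibitor. Compound 1 `O=c1ccc(-c2ccccc2)nn1Cc1noc(-c2ccc(C3=NCCN3)cc2)n1` gives > 100000 nM, which is a limit of the assay rather than a number. Compound 2 `c1ccc(OCc2noc(-c3ccc(C4=NCCN4)cc3)n2)cc1` gives > 100000 nM, again only a limit. Compound 3 `c1ccc(-c2ccc(-c3noc(-c4ccc(C5=NCCN5)cc4)n3)cc2)cc1` gives > 100000 nM, also a limit. Compound 2 thus stands where every compound shown stands, at the limit of > 100000 nM in this assay, at which 3 of the 3 values shown sit. Compound 4 `Clc1ccc(-c2noc(-c3ccc(C4=NCCN4)cc3)n2)cc1Cl` has not been measured yet; it differs from compound 2 by 3,4-dichlorophenyl in place of phenoxymethyl on an aromatic carbon. Compound 3 shows that another large aromatic group at the same place still gives only a limit, > 100000 nM. Among the measured compounds shown here, with no measured step to guide the size of the change, no move beyond the scatter is expected from compound 2 to compound 4, a step that the limit leaves unreadable from compound 2 to compound 4. Compound 4 is expected to give about 150000 nM, most likely again as a limit, within a range from 30000 nM to 500000 nM.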

Compound 4, half-maximal inhibitory concentration: 1110 nM
Estimate against measurement, compound 4: 140-fold (2.13 log units) above; the measured number lies below the stated range.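

On this aromatic carbon of the five-membered ring, the group attached decides whether inhibition can be read at all: 3,4-dichlorophenyl in place of phenoxymethyl gives an at least 90-fold lower number from compound 2 to compound 4 (1.95 log units; beyond the scatter) in this assay. An aromatic ring at this place is not enough by itself, as compound 3 gives > 100000 nM, which is a limit. From the compounds shown here alone, the true size of the step stays unknown, as compound 2 also gives only a limit: the limit of > 100000 nM in this assay, at which 3 of the 4 values shown sit.

Still open, going by these compounds, is whether a single chlorine would serve as well as two. On these data alone, it is also open whether an amine or a carboxylic acid on that phenyl ring would keep the gain.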